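The source may hold more compounds than are shown below. What is called first, only, known or untested is meant among the compounds shown, and "the series" means these compounds.

In a functional assay on the whole organism for inhibition, with Rattus norvegicus as the target, in the maximal electroshock model, at a dose of 25 mg/kg by the intraperitoneal route (on this read-out lower numbers stand for less inhibition and higher numbers for more inhibition at the one dose given (going by the name of the read-out)), compound 3 `CN(C)c1ncnc2c1ncn2Cc1ccc(F)cc1` gives 33%, the highest of the three measured numbers. Compound 1 `CN(C)c1ncnc2c1ncn2Cc1ccc(Cl)cc1` gives 0%, and compound 2 `Cc1ccc(Cn2cnc3c(N(C)C)ncnc32)cc1` gives 0%. Compound 4 `COc1ccc(Cn2cnc3c(N(C)C)ncnc32)cc1` has not yet been measured; it differs from compound 3 in one place: methoxy in place of fluoro on an aromatic carbon. For the measured compounds named here, two measured steps bear on this, each swapping another group for fluoro on the same aromatic carbon: a number 33 percentage points higher from compound 1 to compound 3 (beyond the scatter) and a number 33 percentage points higher from compound 2 to compound 3 (beyond the scatter). Both groups tried there in place of fluoro gave no inhibition, so a fall beyond the scatter is expected for compound 4, of the size a number 28 percentage points lower from compound 3 to compound 4 (beyond the scatter), with the caution that methoxy itself has not been tried. Compound 4 is expected to give 5%, somewhere between 0% and 30%.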

Compound 4, a percentage reported as inhibition, in the whole organism at one dose (the size of the read-out at that dose, not a potency): 0%
For compound 4 the middle estimate is 5 percentage points above the measured one; the measured number falls inside the stated range.
By their numbers in this assay, from the lowest: compounds 1, 2 and 4 (each within the scatter of the next); then compound 3.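

Methoxy at this aromatic carbon does not keep the inhibition seen with fluoro in this assay, giving a number 33 percentage points lower from compound 3 to compound 4 (beyond the scatter) here. Methoxy also cannot be told apart from the other two groups, with no change at the digits printed from compound 2 to compound 4 (within the scatter) and no change at the digits printed from compound 1 to compound 4 (within the scatter), so fluoro alone of these four groups gives a reading above zero at this dose. No measurement shown accounts for this difference. On these data alone, whether bare hydrogen, an amine or a nitrile at this carbon would match fluoro remains open. So does whether moving fluoro elsewhere on the ring would keep the inhibition.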